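Adding Chloro to Compound 1: An Expected Shift

The compounds below may be only part of what the source reports. "The series", "measured", "known", "first", "only" and "open" are said of these compounds alone.

Compound 1 `CCCCCn1c(N)nc2ccccc21` is the reference point of this small set. For the measured compounds named here, in an assay on HEK293 cells for agonist activity at Toll-like receptor 8 (Homo sapiens), read by reporter gene assay (on this read-out higher numbers stand for an effect only at larger amounts of compound and lower numbers for an effect already at smaller amounts), compound 1 gives 3230 nM, the lowest of the three numbers available so far. Two neighbours carry a methyl in place of hydrogen on an aromatic carbon of the shared core. Compound 2 `CCCCCn1c(N)nc2ccc(C)cc21` gives 7210 nM in this assay, and compound 3 `CCCCCn1c(N)nc2cccc(C)c21` gives 6610 nM. The steps are a 2.2-fold higher number from compound 1 to compound 2 (0.35 log units; beyond the scatter) and a 2.0-fold higher number from compound 1 to compound 3 (0.31 log units; beyond the scatter): both modest, both beyond the scatter, both toward an effect only at larger amounts.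

Compound 4 `CCCCCn1c(N)nc2c(Cl)cccc21` has not yet been measured. It differs from compound 1 by chloro in place of hydrogen on an aromatic carbon. Going by the values given here, no measured step places chloro on this core, and no measured step touches the place described here; the two methyl steps are the only guide, and they bear on it only loosely, as examples of a single small group added to the six-membered aromatic ring of carbon only. On that basis a modest rise of the number in this assay is expected, of about the size already seen: the step from compound 1 to compound 4 is estimated as a 1.9-fold higher number from compound 1 to compound 4 (0.27 log units; within the scatter). For compound 4 the expected value is 6000 nM, within a range from 2500 nM to 15000 nM.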

Compound 4, half-maximal effective concentration: "not active" (no number reported)
For compound 4 the study gives words and no number; there is nothing to compare the estimate with.
By their numbers in this assay, from the lowest: compound 1; then compounds 3 and 2 (each within the scatter of the next).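

In this assay, for the compounds shown here, compound 4 is reported only in words, as "not active", so no step from compound 1 to compound 4 can be read. Nothing available bears on this result. The compounds shown leave open whether a methyl in the place of the chloro of compound 4 would give a number in this assay.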